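The source may hold more compounds than are shown below. What is called first, only, known or untested is meant among the compounds shown, and "the series" means these compounds.

Measured compounds:
compound 1, `Cc1cn2cccc(OCc3ccccc3)c2n1`, 70%
compound 2, `Cc1nc2c(OCc3ccccc3)cccn2c1CCC#N`, 20%
compound 3, `Cc1nc2c(OCc3ccccc3)cccn2c1CO`, 80%

All three were run in a functional assay on the whole organism (stomach) for inhibition, with Canis familiaris (Canis lupus familiaris) as the target, at a dose of 5 mg/kg by the intravenous route; on this read-out higher numbers stand for a stronger effect at the one dose given and lower numbers for a weaker effect. On these numbers compound 1 stands second highest of three; the nearer step is a number 10 percentage points higher from compound 1 to compound 3 (within the scatter) and the further one is a number 50 percentage points lower from compound 1 to compound 2 (beyond the scatter).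

Compound 4, `CCOCc1c(C)nc2c(OCc3ccccc3)cccn12`, is not yet measured. It differs from compound 1 by ethoxymethyl in place of hydrogen on an aromatic carbon.

Within the data shown here, two measured steps bear on this change, both replacing the same hydrogen on the shared core of compound 1: a number 50 percentage points lower from compound 1 to compound 2 (beyond the scatter) and a number 10 percentage points higher from compound 1 to compound 3 (within the scatter). The pair of substituted compounds also gives a number 60 percentage points higher from compound 2 to compound 3 (beyond the scatter). The entering ethoxymethyl group matches the 2-cyanoethyl group in heavy-atom count and in having one acceptor and no donor, whereas hydroxymethyl carries a donor. The expectation is therefore a downward step, a number 20 percentage points lower from compound 1 to compound 4 (beyond the scatter), though its size is poorly fixed by only these two comparisons.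

Compound 4 is estimated at 50% in this assay, with a range from 15% to 85%.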

Compound 4, a percentage reported as inhibition, in the whole organism at one dose (the size of the read-out at that dose, not a potency): 35%
For compound 4 the middle estimate is 15 percentage points above the measured one, within the range that was stated.
By their numbers in this assay, from the lowest: compound 2; then compound 4; then compounds 1 and 3 (each within the scatter of the next).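

In this assay the ethoxymethyl group on this aromatic carbon gives a number 35 percentage points lower from compound 1 to compound 4 (beyond the scatter) and so a large fall at this position is not confined to the 2-cyanoethyl group. Ethyl in place of the hydrogen on the oxygen of hydroxymethyl gives a number 45 percentage points lower from compound 3 to compound 4 (beyond the scatter) and this single change separates the two oxygen-bearing side chains, while a number 15 percentage points higher from compound 2 to compound 4 (beyond the scatter) is a modest step that leaves the ethoxymethyl compound above the nitrile. Nothing at hand accounts for these steps.

Open, as far as these compounds go, is whether methoxymethyl on the same carbon would stay with compound 3 or fall towards compound 4, which would show how much of the ethyl is needed for the loss. Aminomethyl and a carboxylic acid at this position would test whether the high read-out of compound 3 extends beyond hydroxymethyl.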